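The source may hold more compounds than are shown below. What is called first, only, known or untested is meant among the compounds shown, and "the series" means these compounds.

Measured in a functional assay on BMMC cells (Mus musculus, strain C57BL/6) for inhibition, with stated times of 5 days and 48 h; a lower number here means a stronger inhibitor, a higher number a weaker inhibitor:
compound 1, `C=C1CC[C@@H]2[C@](C)(CNCc3ccc(C#N)cc3)[C@H](O)CC[C@@]2(C)[C@@H]1/C=C/C1=CCOC1=O`: 1130 nM
compound 2, `C=C1CC[C@@H]2[C@](C)(CNCc3ccncc3)[C@H](O)CC[C@@]2(C)[C@@H]1/C=C/C1=CCOC1=O`: 2030 nM
compound 3, `C=C1CC[C@@H]2[C@](C)(CNCc3nccs3)[C@H](O)CC[C@@]2(C)[C@@H]1/C=C/C1=CCOC1=O`: 700 nM

Compound 3 holds the lowest of the three numbers; its step to compound 1 is within the scatter, a 1.6-fold lower number from compound 1 to compound 3 (0.21 log units; within the scatter), while its step to compound 2 is beyond it, a 2.9-fold lower number from compound 2 to compound 3 (0.46 log units; beyond the scatter). Compound 4, `C=C1CC[C@@H]2[C@](C)(CNCc3ccc4c(c3)CC=N4)[C@H](O)CC[C@@]2(C)[C@@H]1/C=C/C1=CCOC1=O`, is not yet measured in this assay. It differs from compound 3 only at the group on the saturated chain carbon bound to the amine nitrogen: a group of 9 heavy atoms (8 carbon, 1 nitrogen; one five-membered non-aromatic ring with 1 hetero atom, one six-membered aromatic ring of carbon only) in place of a group of 5 heavy atoms (3 carbon, 1 nitrogen, 1 sulfur; one five-membered aromatic ring with 2 hetero atoms), on a saturated chain carbon bound to an amine nitrogen. All three measured steps alter this same group and stay in a narrow span: a 1.8-fold higher number from compound 1 to compound 2 (0.25 log units; within the scatter) and a 1.6-fold lower number from compound 1 to compound 3 (0.21 log units; within the scatter) are within the scatter, and only a 2.9-fold lower number from compound 2 to compound 3 (0.46 log units; beyond the scatter) reaches beyond it. Going by the values given here, the group entering compound 4 is larger than any tried so far and brings a non-aromatic five-membered ring that no measured compound has, so no step speaks directly to it. The expectation for compound 4 is therefore a step of a 1.6-fold higher number from compound 3 to compound 4 (0.20 log units; within the scatter) toward a somewhat higher number, not clearly beyond the scatter. Compound 4 is estimated at 1100 nM, with a range from 450 nM to 2700 nM.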

Compound 4, half-maximal inhibitory concentration: 550 nM
Beside the measured number, compound 4's estimate is 2.0-fold (0.30 log units) above it; low and high end bracket the measured number.
By their numbers in this assay, from the lowest: compounds 4, 3, 1 and 2 (each within the scatter of the next, the first and the last beyond it).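

In this assay, the place on a saturated chain carbon bound to an amine nitrogen tolerates a two-ring group with more heavy atoms than any group before it: compound 4 cannot be told apart from compound 3 (a 1.3-fold lower number from compound 3 to compound 4 (0.10 log units; within the scatter)). Unlike compound 3, compound 4 also stands beyond the scatter from both compound 1 (a 2.1-fold lower number from compound 1 to compound 4 (0.31 log units; beyond the scatter)) and compound 2 (a 3.7-fold lower number from compound 2 to compound 4 (0.57 log units; beyond the scatter)), so neither the larger size nor the non-aromatic five-membered ring costs activity in this small set. No supporting data accompany these numbers, so the result stays without any explanation.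

Which of the two rings in the entering group matters remains open. So does the outcome of a carboxylic acid or a longer alkyl chain in this place.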